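The source may report more compounds than this note shows. Statements on the series, on what has been measured and on what is new or still open speak of the compounds shown alone.

Compounds 1, 2 and 3 share one core, seen in compound 1 `CCc1cccc2c(=O)c(-c3nn[nH]n3)c[nH]c12`, compound 2 `Cc1ccc2[nH]cc(-c3nn[nH]n3)c(=O)c2c1` and compound 3 `O=c1c(-c2nn[nH]n2)c[nH]c2c(C(F)(F)F)cccc12`. In a functional assay on the whole organism (strain Sprague-Dawley) for inhibition, with Rattus norvegicus as the target (a higher number here means that more compound is needed for the effect, a lower number that less compound is needed), compound 1 gives only a limit of the assay, > 25 mg/kg. In this assay compound 2 likewise gives only a limit, > 25 mg/kg. Compound 3 too gives only a limit, > 25 mg/kg. For the measured compounds named here, the one measured step between neighbours in this assay, a step that the two limits leave unreadable from compound 1 to compound 3, cannot be read because both of its ends are limits. Compound 3 therefore stands where all three measured values sit, namely at the limit of > 25 mg/kg in this assay, at which 3 of the 3 values shown sit, and no number is known for it.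

Compound 4 `CS(=O)(=O)c1cccc2c(=O)c(-c3nn[nH]n3)c[nH]c12` differs from compound 3 in one place: methylsulfonyl in place of trifluoromethyl on an aromatic carbon. Going by the values given here, no measured step bears on this change, and the single step that touches compound 3 is unreadable, so the measured data give neither a direction nor a size for the change in this assay. Compound 4 is therefore expected to give about 25 mg/kg in this assay, within a range from 10 mg/kg to 60 mg/kg, and most probably again as a limit rather than a number. The step this estimate means, a number no higher from compound 3 to compound 4 (the limit leaves the size open), is expected to stay within the scatter.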

Compound 4, minimum effective dose: > 25 mg/kg
Compound 4 ended at the assay's limit (the forecaster's own chance of this, stated with the estimate: 75%); the middle value lies on the limit itself.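

Compound 4 gives only a limit in this assay, so neither of its steps, to compound 3 or to compound 1, can be read, and the four compounds stand together: the limit of > 25 mg/kg in this assay, at which 4 of the 4 values shown sit. The compounds shown leave open whether any of these groups on the shared core changes the minimum effective dose in this assay, as none gives a number.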